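From 4-chlorophenyl to 3-nitrophenyl on the aromatic nitrogen

A few compounds are considered here, and "the series" means these few. Any claim that something is new, unique, unknown or untested is made for them only; others in the source may bear on it.

In a functional assay on HepG2 cells (Homo sapiens) for inhibition, read by MTT assay, with a stated time of 72 h (on this read-out higher numbers stand for weaker inhibition and lower numbers for stronger inhibition), compound 1 (`Cc1cc2occ(-c3nc(-c4ccccc4)c(-c4ccccc4)n3-c3ccc(Cl)c(Cl)c3)c(=O)c2cc1Cl`) gives 12500 nM, compound 2 (`Cc1ccc(-n2c(-c3coc4cc(C)c(Cl)cc4c3=O)nc(-c3ccccc3)c2-c2ccccc2)c(C)c1`) gives 3120 nM and compound 3 (`Cc1cc2occ(-c3nc(-c4ccccc4)c(-c4ccccc4)n3-c3ccc(Cl)cc3)c(=O)c2cc1Cl`) gives 1560 nM. Compound 3 thus stands clear of compound 1 but within the scatter of compound 2. Compound 4 (`Cc1cc2occ(-c3nc(-c4ccccc4)c(-c4ccccc4)n3-c3cccc([N+](=O)[O-])c3)c(=O)c2cc1Cl`) carries 3-nitrophenyl in place of 4-chlorophenyl on an aromatic nitrogen. Within the data shown here, two measured steps bear on this group. Hydrogen in place of chloro gave an 8.0-fold lower number from compound 1 to compound 3 (0.90 log units; beyond the scatter), and 4-chlorophenyl in place of 2,4-dimethylphenyl gave a 2.0-fold lower number from compound 2 to compound 3 (0.30 log units; within the scatter). Among the measured compounds shown here, no measured compound carries a nitro group, so the expectation is loose: a modest move to a higher number. The expected step is a 2.2-fold higher number from compound 3 to compound 4 (0.35 log units; beyond the scatter). For compound 4 the estimated value is 3500 nM, with an expected range from 1000 nM to 12500 nM.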

Compound 4, half-maximal inhibitory concentration: 25000 nM
Beside the measured number, compound 4's estimate is 7.1-fold (0.85 log units) below it; measured number outside the range, above it.
By their numbers in this assay, from the lowest: compounds 3 and 2 (each within the scatter of the next); then compounds 1 and 4 (each within the scatter of the next).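

In this assay, the aromatic nitrogen proves able to carry a group that costs far more than the earlier changes among chlorophenyl and methylphenyl groups suggested: 3-nitrophenyl gives a 16-fold higher number from compound 3 to compound 4 (1.20 log units; beyond the scatter) and an 8.0-fold higher number from compound 2 to compound 4 (0.90 log units; beyond the scatter). Against 3,4-dichlorophenyl it gives a 2.0-fold higher number from compound 1 to compound 4 (0.30 log units; within the scatter), so two quite different groups on this nitrogen now share the high end of the series. No measurement shown explains this result. The compounds shown leave open whether the nitro group itself or its place on the phenyl ring sets the number, and how a phenyl ring bearing an amine or a carboxylic acid would read here.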